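Swapping the Amide Aryl Group for a Thiazole

The source may report more compounds than this note shows. Statements on the series, on what has been measured and on what is new or still open speak of the compounds shown alone.

Among the compounds with values here, compound 2 `COc1ccccc1NC(=O)c1c(O)c2cccnc2n(-c2ccccc2)c1=O` stands lowest of the two numbers measured so far in a functional assay on the whole organism for inhibition, with Rattus norvegicus as the target, read by cytopathic effect and paw edema, at a dose of 100 mg/kg by the oral route (on this read-out lower numbers stand for less inhibition and higher numbers for more inhibition at the one dose given (going by the name of the read-out)), giving -10.1%. Within the data shown here, compound 1 `O=C(Nc1cccc(Cl)c1)c1c(O)c2cccnc2n(-c2ccccc2)c1=O` gives 13.4% in this assay, and the one measured change, a number 23.5 percentage points lower from compound 1 to compound 2 (beyond the scatter), shows that exchanging the group on the amide-type nitrogen can shift the read-out by a modest amount. Compound 3 `O=C(Nc1nccs1)c1c(O)c2cccnc2n(-c2ccccc2)c1=O` has not been measured and differs from compound 2 in one place: 1,3-thiazol-2-yl in place of 2-methoxyphenyl on an amide-type nitrogen. The measured step between compound 1 and compound 2 also exchanges the group on the amide-type nitrogen. It gives no direction for a 1,3-thiazol-2-yl group; a shift of about that size up or down, or none beyond the scatter, seems possible. For compound 3 the expected value in this assay is 5%, within a range from -20% to 30%. That amounts to an expected step of a number 15.1 percentage points higher from compound 2 to compound 3 (beyond the scatter).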

Compound 3, a percentage reported as inhibition, in the whole organism at one dose (the size of the read-out at that dose, not a potency): 2.5%
Beside the measured number, compound 3's estimate is 2.5 percentage points above it, and the stated range covers the measured number.
By their numbers in this assay, from the lowest: compound 2; then compound 3; then compound 1.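

Within the data shown here, until this result, only substituted phenyl rings stood on the amide-type nitrogen. The 1,3-thiazol-2-yl group shows that a five-membered aromatic ring with 2 hetero atoms can stand there too, and in this assay its number falls between those of the two phenyl compounds: a number 12.6 percentage points higher from compound 2 to compound 3 (beyond the scatter), yet a number 10.9 percentage points lower from compound 1 to compound 3 (beyond the scatter). Both steps are modest, so across these three compounds, changing from a phenyl ring to this thiazole does not take the read-out outside the span the phenyl rings already mark. Nothing at hand explains why the number lands where it does.

Going by these compounds, it remains open whether a non-aromatic group on this nitrogen, such as a cyclohexyl ring or a longer chain ending in an amine, would move the number beyond this span. A six-membered ring holding nitrogen, such as pyridine, also remains an open case.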